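The compounds below may be only part of what the source reports. "The series", "measured", "known", "first", "only" and "open" are said of these compounds alone.

In an assay on isolated protein for binding affinity to corticotropin-releasing factor receptor 1 (Homo sapiens) (a lower number here means a stronger inhibitor, a higher number a weaker inhibitor), compound 1 `C=CCN(CC=C)c1nc(C)nc(Nc2c(C)cc(C)cc2C)n1` gives 115 nM. Compound 2 `CCCN(Cc1ccccc1)c1nc(C)nc(Nc2ccc(C)cc2)n1` reaches only the limit of this assay, at > 10000 nM. Compound 3 `CCN(Cc1ccccc1)c1nc(C)nc(Nc2ccc(C)cc2)n1` likewise reaches only the limit, at > 10000 nM. The step that the two limits leave unreadable from compound 2 to compound 3 therefore cannot be read, and compound 3 stands at the limit of > 10000 nM in this assay, at which 2 of the 3 values shown sit, with no number of its own.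

Compound 4 `CCN(Cc1ccccc1)c1nc(C)nc(Nc2c(C)cccc2C)n1` differs from compound 3 by 2,6-dimethylphenyl in place of 4-methylphenyl on a nitrogen on an aromatic ring. Among the compounds with values here, no measured step covers this change: the only measured step is the one from compound 2 to compound 3, which is unreadable, and compound 1, the one compound with a number, carries a 2,4,6-trimethylphenyl group on the same nitrogen together with two allyl chains rather than ethyl and benzyl, so it shows only what its own value shows. Since compound 3 sits at a limit, the step of an at least 12-fold lower number from compound 3 to compound 4 (1.09 log units; beyond the scatter) is expected as a gain of unknown but possibly large size, its lower bound set by that limit. Compound 4 is therefore estimated at 800 nM, within 100 nM to 8000 nM.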

Compound 4, inhibition constant: > 10000 nM
Compound 4: a limit, no number (the forecaster's own chance of this, stated with the estimate: 25%); at least 12-fold (1.09 log units) between middle value and limit.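

Compound 3 and compound 4 both sit at a limit in this assay, so no step between them can be read: the limit of > 10000 nM in this assay, at which 3 of the 4 values shown sit.

The compounds shown leave open whether 2,6-dimethylphenyl in place of 4-methylphenyl changes the affinity at all, and which of the differences from compound 1 goes with its value of 115 nM.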